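A few compounds are considered here, and "the series" means these few. Any claim that something is new, unique, unknown or untested is made for them only; others in the source may bear on it.

The study compares two measured compounds and a third awaiting measurement in a functional assay on MCF7 cells (Homo sapiens) for cytotoxicity, read by MTT assay, with a stated time of 72 h; a lower number here means a stronger inhibitor, a higher number a weaker inhibitor. Compound 1 `Cc1nnc(Sc2c(C)oc3ccccc3c2=O)o1` gives only a limit there, > 50000 nM, and not a number. Compound 2 `Cc1ccc2oc(CSc3nc4nc(C)cc(C)n4n3)cc(=O)c2c1` likewise reaches only a limit, > 25000 nM. Both values shown are therefore limits, one sitting at the limit of > 25000 nM in this assay, at which 1 of the 2 values shown sits, and one at the limit of > 50000 nM in this assay, at which 1 of the 2 values shown sits, so compound 2 cannot be ordered against compound 1 on these numbers. Compound 3 `Cc1cc(C)n2nc(SCc3cc(=O)c4cc(Cl)ccc4o3)nc2n1` differs from compound 2 by chloro in place of methyl on an aromatic carbon, the chloro entering on an aromatic carbon of a six-membered aromatic ring of carbon only, part of a fused system of two rings. Going by the values given here, no measured step guides this change, so the expected step in this assay is none beyond the scatter, leaving compound 3 most likely at a limit again. The estimate for compound 3 is 40000 nM, with a range from 10000 nM to 150000 nM. The expected step that the limit leaves unreadable from compound 2 to compound 3 thus amounts to little change.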

Compound 3, half-maximal inhibitory concentration: > 25000 nM
Compound 3: only a limit was reported; the forecaster's own chance of this, stated with the estimate: 80%; the middle value is on the limit's open side.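

Going by these compounds alone, compound 3, like compound 2, reaches only a limit in this assay, so no step between compound 2 and compound 3 can be read. The compounds shown leave open whether chloro in place of methyl changes the cytotoxicity at all, and what actual value any of them would give.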